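Methoxy to trifluoromethyl on the aromatic ring

The compounds below may be only part of what the source reports. "The series", "measured", "known", "first", "only" and "open" are said of these compounds alone.

Measured compounds in a functional assay (muscle tissue) for inhibition, with Cavia porcellus as the target; a lower number here means a stronger inhibitor, a higher number a weaker inhibitor:
Compound 1 `CO/C(O)=C1\C(C)=NC(C)=C(C(=O)OCC(C)C)C1c1cccc([N+](=O)[O-])c1` gives 0.59 nM.
Compound 2 `CO/C(O)=C1\C(C)=NC(C)=C(C(=O)OCC(C)C)C1c1cccc(OC)c1` gives 7.1 nM.
Compound 3 `CO/C(O)=C1\C(C)=NC(C)=C(C(=O)OCC(C)C)C1c1ccccc1C(F)(F)F` gives 2.1 nM.

Compound 2 holds the highest number of the three in this assay. Its nearest neighbour is compound 3, whose value sits well below it, and the furthest is compound 1. Going by the values given here, the one single-point step available, a 12-fold higher number from compound 1 to compound 2 (1.08 log units; beyond the scatter), shows that the substituent on the six-membered aromatic ring of carbon only moves this assay strongly.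

Compound 4 `CO/C(O)=C1\C(C)=NC(C)=C(C(=O)OCC(C)C)C1c1cccc(C(F)(F)F)c1` is the next member. Relative to compound 2 the change is trifluoromethyl in place of methoxy on an aromatic carbon, on an aromatic carbon of a six-membered aromatic ring of carbon only, meta to a large group. Among the compounds with values here, no measured step covers this exact swap; compound 3 carries the same group elsewhere on that ring, and its value is lower than that of compound 2, but no step is drawn between the two. The bearing step is therefore a 12-fold higher number from compound 1 to compound 2 (1.08 log units; beyond the scatter), which says that leaving methoxy for another group can shift this assay by a large amount, here expected downward.

Compound 4 is accordingly expected to give 1.5 nM in this assay, within 0.5 nM to 5 nM. For compound 4 the estimated step is a 4.7-fold lower number from compound 2 to compound 4 (0.68 log units; beyond the scatter).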

Compound 4, half-maximal inhibitory concentration: 15 nM
Compound 4: middle estimate off by 10-fold (1.00 log units), on the low side; measured number above the stated range.
By their numbers in this assay, from the lowest: compound 1; then compound 3; then compound 2; then compound 4.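

In this assay, going by these compounds alone, trifluoromethyl in place of methoxy on the aromatic carbon meta to a large group gives a 2.1-fold higher number from compound 2 to compound 4 (0.32 log units; beyond the scatter), so leaving methoxy does not by itself lower the number at this place, while the change from nitro to trifluoromethyl gives a 25-fold higher number from compound 1 to compound 4 (1.41 log units; beyond the scatter), which leaves nitro as the only one of the three groups here with a low number. Trifluoromethyl also does not carry a low number wherever it stands on this ring: compound 3, with the group elsewhere on that ring, gives 2.1 nM, whereas compound 4 gives 15 nM, so the lower value of compound 3 cannot be transferred to this place. No measurement at hand accounts for the order of the three groups at this place.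

From the compounds shown here alone, whether a nitrile, an amine or a carboxylic acid on this aromatic carbon would fall nearer to nitro or to methoxy remains open. Also open, going by these compounds, is whether the order of nitro, methoxy and trifluoromethyl would hold with a longer chain on the ester.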